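Acid for Base on the Chain End of a Stilbene Ether

The source may hold more compounds than are shown below. What is called first, only, known or untested is meant among the compounds shown, and "the series" means these compounds.

Of the compounds shown here, three have been tested in a functional assay on the whole organism with Mus musculus as the target, in the maximal electroshock model, at a dose of 50 mg/kg by the oral route; on this read-out higher numbers stand for more inhibition at the one dose given (going by the name of the read-out) and lower numbers for less inhibition. Compound 1 `CN(C)CCCOc1ccccc1/C=C/c1ccccc1` gives 14.2% in this assay. Compound 2 `CN(C)CCCCOc1cccc(/C=C/c2ccccc2)c1`, which carries its chain on a different position of the ring, gives 0%. Compound 3 `CCN1CCN(CCCCOc2ccccc2/C=C/c2ccccc2)CC1` gives 33.3% in this assay and so stands highest of the three, with compound 1 nearest and compound 2 furthest.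

One step joins two of these compounds by a single change: a number 19.1 percentage points higher from compound 1 to compound 3 (beyond the scatter), where a larger saturated ring amine replaced a small open-chain amine at the end of the linker.

Compound 4 `O=C(O)C1CCCN(CCCCOc2ccccc2/C=C/c2ccccc2)C1` differs from compound 3 by 3-carboxypiperidin-1-yl in place of 4-ethylpiperazin-1-yl on a saturated chain carbon, four bonds along the chain from an oxygen on an aromatic ring. Among the measured compounds shown here, no measured pair covers a change of this kind: the only amine swap seen so far, the step from compound 1 to compound 3, exchanged one base for another, whereas here a carboxylic acid enters and the second nitrogen leaves. That step therefore gives little guidance, and the expected step from compound 3 to compound 4 is a fall, a number 18.3 percentage points lower from compound 3 to compound 4 (beyond the scatter), within wide uncertainty. Compound 4 is thus estimated to give 15% in this assay, in the range from 0% to 40%.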

Compound 4, a percentage reported as inhibition, in the whole organism at one dose (the size of the read-out at that dose, not a potency): 12.5%
The estimate for compound 4 lay 2.5 percentage points above the measured number; the range from low to high includes it.
By their numbers in this assay, from the lowest: compound 2; then compounds 4 and 1 (each within the scatter of the next); then compound 3.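

In this assay, 3-carboxypiperidin-1-yl in place of 4-ethylpiperazin-1-yl on a saturated chain carbon, four bonds along the chain from an oxygen on an aromatic ring, gives a number 20.8 percentage points lower from compound 3 to compound 4 (beyond the scatter). The earlier step from an open-chain amine to a ring amine left open whether a six-membered non-aromatic ring at this place was enough to hold the higher number, and this pair shows that it is not, since both groups carry such a ring. This single swap removes a ring nitrogen and brings in a carboxylic acid together, so the step belongs to the whole change and cannot be split between the two, and nothing at hand explains the fall.

A plain piperidin-1-yl group on the same chain would separate the loss of the second nitrogen from the arrival of the acid, while the methyl ester of compound 4 would show whether the free carboxylic acid matters. On these data alone, it also remains open whether 4-carboxypiperidin-1-yl, with the acid elsewhere on the ring, would give a similar number.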